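A few compounds are considered here, and "the series" means these few. Any claim that something is new, unique, unknown or untested is made for them only; others in the source may bear on it.

Measured compounds:
- compound 1, `O=C(N/N=C/c1cccc(F)c1)c1cccnc1Nc1cccc(C(F)(F)F)c1`: 52.8%
- compound 2, `O=C(N/N=C/c1cccc(Cl)c1)c1cccnc1Nc1cccc(C(F)(F)F)c1`: 63.5%
- compound 3, `O=C(N/N=C/c1ccc(Cl)cc1)c1cccnc1Nc1cccc(C(F)(F)F)c1`: 52.8%

In a functional assay on the whole organism (strain Wistar) for inhibition, with Rattus norvegicus as the target, read by paw edema, with a stated time of 2 h, at a dose of 10 mg/kg by the intraperitoneal route (on this read-out lower numbers stand for less inhibition and higher numbers for more inhibition at the one dose given (going by the name of the read-out)), compound 1 gives 52.8%. On that number compound 1 stands level with compound 3, and together they are the lowest of the three values. Among the compounds with values here, the one compound clearly apart is compound 2, reached by the step of a number 10.7 percentage points higher from compound 1 to compound 2 (beyond the scatter). The other two measured steps are no change at the digits printed from compound 1 to compound 3 (within the scatter) and a number 10.7 percentage points lower from compound 2 to compound 3 (beyond the scatter).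

Compound 4, `O=C(N/N=C/c1cccnc1)c1cccnc1Nc1cccc(C(F)(F)F)c1`, is not yet measured. Next to compound 1 it differs by pyridin-3-yl in place of 3-fluorophenyl on a carbon with a double bond to nitrogen. Within the data shown here, none of the measured steps covers a change of this kind: each of them only swaps one halogen for another, or moves a halogen, on the ring that hangs from the carbon with a double bond to nitrogen. They show that small changes on this ring shift the read-out at most modestly, and in two of three cases not beyond the scatter. Nothing measured speaks to exchanging a six-membered aromatic ring of carbon only for a ring with one hetero atom.

Compound 4 is therefore expected to land near compound 1, at an estimated 50%, with a likely range from 35% to 65%. The step this estimate implies is expected to be a number 2.8 percentage points lower from compound 1 to compound 4 (within the scatter), not beyond the scatter.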

Compound 4, a percentage reported as inhibition, in the whole organism at one dose (the size of the read-out at that dose, not a potency): 62.4%
Estimate against measurement, compound 4: 12.4 percentage points below; measured number inside the range.
By their numbers in this assay, from the lowest: compounds 1, 3, 4 and 2 (each within the scatter of the next, the first and the last beyond it).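

In this assay, the place on a carbon with a double bond to nitrogen also accepts a ring that carries a hetero atom and no halogen: the change to pyridin-3-yl gives a number 9.6 percentage points higher from compound 1 to compound 4 (within the scatter), gives a number 9.6 percentage points higher from compound 3 to compound 4 (within the scatter), and gives a number 1.1 percentage points lower from compound 2 to compound 4 (within the scatter). All three steps stay within the scatter, so for these four compounds neither a halogen nor a ring of carbon only is needed for inhibition of this size, and compound 4 cannot be ranked against any of the other three, even though compound 2 and compound 3 are separated from each other. Nothing available here explains why the hetero-atom ring reads as it does.

The compounds shown leave open how pyridin-2-yl or pyridin-4-yl would read at this place, and whether an amine or a carboxylic acid on the ring would be accepted as well. They also leave open how far the result holds with the trifluoromethyl group on the other side of the shared core replaced, and whether the same picture would appear at other doses, since a reading at one dose is not a potency.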